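Trimming a Trimethoxy Group, One Methoxy at a Time

The source may hold more compounds than are shown below. What is called first, only, known or untested is meant among the compounds shown, and "the series" means these compounds.

Three measured compounds share one core and differ in the methoxy groups on one aromatic ring and in the group on the other. In a functional assay on IGROV-1 cells (Homo sapiens) for inhibition, read by sulforhodamine B assay, with a stated time of 48 h (a higher number here means that more compound is tolerated, a lower number that less compound is tolerated), compound 1 `COc1ccc(-c2cc(/C=C/C(=O)c3ccc(N)cc3)[nH]n2)cc1` gives 43300 nM. Compound 2 `COc1cc(-c2cc(/C=C/C(=O)c3ccc(N)cc3)[nH]n2)cc(OC)c1OC` reaches only a limit of this assay, > 100000 nM. Compound 3 `COc1ccc(C(=O)/C=C/c2cc(-c3cc(OC)c(OC)c(OC)c3)n[nH]2)cc1` likewise gives only a limit, > 100000 nM. Compound 2 therefore stands at the top of the numbers shown, together with compound 3, while compound 1 alone gives a real number. Going by the values given here, the single measured step, a step that the two limits leave unreadable from compound 2 to compound 3, cannot be sized because both its compounds sit at the limit of > 100000 nM in this assay, at which 2 of the 3 values shown sit.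

Compound 4 `COc1ccc(-c2cc(/C=C/C(=O)c3ccc(N)cc3)[nH]n2)cc1OC` differs from compound 2 by hydrogen in place of methoxy on an aromatic carbon. Among the compounds with values here, no measured step covers this change; the step from compound 2 to compound 3 concerns the other ring and is unreadable anyway. Within the data shown here, the only guide is compound 1, which carries a single methoxy on that ring and gives 43300 nM. Compound 4, carrying two methoxy groups, is expected to give about 70000 nM, within 30000 nM to 150000 nM. The estimated step from compound 2 to compound 4 is an at least 1.4-fold lower number from compound 2 to compound 4 (0.15 log units; that floor lies within the scatter), and it may well remain hidden because compound 2 sits at the limit of > 100000 nM in this assay, at which 2 of the 3 values shown sit.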

Compound 4, concentration lethal to 50% of the cells: 73000 nM
For compound 4 the middle estimate is 1.0-fold (0.02 log units) below the measured one, and the stated range covers the measured number.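

In this assay, going by these compounds alone, the comparison of compounds 1 and 4 sets two real numbers side by side on this ring for the first time. It shows a 1.7-fold higher number from compound 1 to compound 4 (0.23 log units; within the scatter), so adding a second methoxy group in place of hydrogen gives no difference that stands clear of repeat measurements. Removing the methoxy group that sits ortho to one methoxy group and meta to another gives an at least 1.3-fold lower number from compound 2 to compound 4 (0.13 log units; that floor lies within the scatter), and this step has only a floor rather than a true size because the number for compound 2 is a limit: the limit of > 100000 nM in this assay, at which 2 of the 4 values shown sit.

Going by these compounds, how much the third methoxy group matters therefore stays open, since the true value of compound 2 could lie close to that of compound 4 or far from it. The compounds shown also leave open what a hydroxy group, a fluorine atom or an ethoxy group would do at this position, and whether a change here would give a step that stands clear of the scatter.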